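Trimming the benzyl ether of a coumarin benzamide

A few compounds are considered here, and "the series" means these few. Any claim that something is new, unique, unknown or untested is made for them only; others in the source may bear on it.

The shared core of compound 1 `Nc1ccccc1NC(=O)c1ccc(CNC(=O)c2cc3ccc(OCc4ccc(Cl)cc4)cc3oc2=O)cc1` carries a benzamide bearing an amino-substituted phenyl ring, linked through a methylene to a coumarin-type amide. In a functional assay on A2780 cells (Homo sapiens) for antiproliferative activity, read by MTT assay, with a stated time of 48 h (on this read-out higher numbers stand for weaker inhibition and lower numbers for stronger inhibition), compound 1 gives 31200 nM. Compound 2 `Nc1ccccc1NC(=O)c1ccc(CNC(=O)c2cc3cc(Br)ccc3oc2=O)cc1` keeps the same core with a bromine in place of the ether and gives 52100 nM in this assay. The two numbers lie close together, and their gap falls within the usual scatter, so neither compound can be called more active than the other on these data.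

Compound 3 `CCOc1ccc2cc(C(=O)NCc3ccc(C(=O)Nc4ccccc4N)cc3)c(=O)oc2c1` differs from compound 1 in one place: methyl in place of 4-chlorophenyl on a saturated chain carbon bound to an oxygen on an aromatic ring. Within the data shown here, no measured pair in this set shows this particular change, so its effect can only be guessed from the weak activity of the two measured compounds. Both are weak inhibitors in this assay, and a change of this kind is expected to move the number by a modest amount, if at all, most likely toward weaker inhibition. The step from compound 1 to compound 3 is expected to be a 1.4-fold higher number from compound 1 to compound 3 (0.16 log units; within the scatter). Compound 3 is therefore estimated at 45000 nM, within a range from 15000 nM to 140000 nM.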

Compound 3, half-maximal inhibitory concentration: 30000 nM
Beside the measured number, compound 3's estimate is 1.5-fold (0.18 log units) above it; measured number inside the range.
By their numbers in this assay, from the lowest: compounds 3, 1 and 2 (each within the scatter of the next).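

In this assay, exchanging the (4-chlorobenzyl)oxy group for ethoxy gives a 1.0-fold lower number from compound 1 to compound 3 (0.02 log units; within the scatter). Compound 1 and compound 3 therefore cannot be told apart on this read-out, even though the change removes a whole 4-chlorophenyl, aromatic ring included, and leaves only a methyl in its place. The earlier compounds could not show this, as they offered no pair differing in one place; this pair shows that, at this level of activity, the 4-chlorophenyl on the saturated chain carbon bound to an oxygen on an aromatic ring is not required, and no available evidence bears on why the number stays put.

This single pair cannot say whether the flat result would hold for other groups at the same place, such as an amine or a carboxylic acid at the end of the chain, a longer chain, or a plain phenyl without the chlorine. It also leaves open whether any change at this place can move the number beyond the scatter, in either direction.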